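This account rests on a few compounds, and the source may have more. Where it says the series, first, only, none or still open, it means among the compounds named here.

Among the measured compounds shown here, compound 3 `N#C[C@@]1(NC(=O)[C@@H](CC(=O)N2CCOCC2)CC2Cc3ccccc3C2)CCN(C2CCCCC2)C1` gives 23.1 nM in an assay on isolated protein for inhibition of cathepsin S (Homo sapiens) (a lower number here means tighter binding, a higher number weaker binding), the lowest of the two numbers so far. Compound 2 `N#C[C@@]1(NC(=O)[C@@H](CC(=O)N2CCOCC2)CC2CCCCC2)CCNC1` gives 123 nM in this assay, a gap beyond the scatter. Compound 1 `N#C[C@@]1(NC(=O)[C@@H](CC(=O)N2CCOCC2)CC2CCC(c3ccccc3)CC2)CCN(C2CCCCC2)C1` has "not determined" (no result reported) in this assay. Compound 4 `N#C[C@@]1(NC(=O)[C@@H](CC(=O)N2CCOCC2)CC2CCCCC2)CCN(C2CCCCC2)C1` is not yet measured. The change from compound 3 to compound 4 is cyclohexyl in place of 2,3-dihydro-1H-inden-2-yl on a saturated chain carbon, two bonds along the chain from a carbonyl carbon. Compound 2 also carries cyclohexylmethyl on that chain carbon, but it differs from compound 4 at a second place as well, so no shown step isolates this change. A moderate weakening of binding, beyond the scatter, is expected for compound 4, as a 2.4-fold higher number from compound 3 to compound 4 (0.38 log units; beyond the scatter). Compound 4 is expected at 55 nM, within 20 nM to 150 nM.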

Compound 4, dissociation constant: 17.8 nM
Beside the measured number, compound 4's estimate is 3.1-fold (0.49 log units) above it, and the stated range ends above it.
By their numbers in this assay, from the lowest: compounds 4 and 3 (each within the scatter of the next); then compound 2.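

In this assay, cyclohexyl in place of 2,3-dihydro-1H-inden-2-yl on the saturated chain carbon gives a 1.3-fold lower number from compound 3 to compound 4 (0.11 log units; within the scatter), so this position accepts either group at this level of binding, and the aromatic ring of the leaving group is not required. Cyclohexyl in place of hydrogen on the amine nitrogen in a ring gives a 6.9-fold lower number from compound 2 to compound 4 (0.84 log units; beyond the scatter), the first isolated reading at that place. No measured data account for either step. Still open, from the compounds shown here alone, is whether methyl or acetyl on that nitrogen matches cyclohexyl. A hydroxyl on the cyclohexyl at the chain carbon is equally untested in these compounds.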